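Swapping tert-Butyl for Bromo on the Aryl Ring

The compounds below may be only part of what the source reports. "The series", "measured", "known", "first", "only" and "open" are said of these compounds alone.

Compound 1, `O=C1C=CC(OCC(F)(F)F)N1c1ccccc1`: 23400 nM
Compound 2, `CC(C)(C)c1ccc(N2C(=O)C=CC2OCC(F)(F)F)cc1`: 8500 nM

Of the compounds shown here, two share one core and have been measured in a functional assay on A549 cells (Homo sapiens) for inhibition; on this read-out higher numbers stand for weaker inhibition and lower numbers for stronger inhibition. Compound 1 gives 23400 nM, while compound 2 gives 8500 nM. Going by the values given here, compound 2 therefore has the lower of the two numbers, and the single step measured so far, a 2.8-fold lower number from compound 1 to compound 2 (0.44 log units; beyond the scatter), comes from placing a tert-butyl group where compound 1 carries only hydrogen.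

Compound 3, `O=C1C=CC(OCC(F)(F)F)N1c1ccc(Br)cc1`, has not yet been measured. It differs from compound 2 in one way: bromo in place of tert-butyl on an aromatic carbon. The step from compound 1 to compound 2 is the only one that bears on this change, since it concerns the same position on the same ring. There, adding four carbons lowered the number modestly. Bromo is a single heavy atom, so compound 3 sits between compound 1 and compound 2 in what occupies that position, and a number between their two values is expected, giving a small rise a 1.4-fold higher number from compound 2 to compound 3 (0.15 log units; within the scatter) that may not clear the scatter. Compound 3 is estimated at 12000 nM, with a range from 5000 nM to 30000 nM.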

Compound 3, half-maximal inhibitory concentration: 6960 nM
For compound 3 the middle estimate is 1.7-fold (0.24 log units) above the measured one; the range from low to high includes it.
By their numbers in this assay, from the lowest: compounds 3 and 2 (each within the scatter of the next); then compound 1.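

In this assay, bromo in place of tert-butyl on the aromatic carbon gives a 1.2-fold lower number from compound 2 to compound 3 (0.09 log units; within the scatter), so compound 2 and compound 3 cannot be told apart on this read-out, while bromo in place of hydrogen gives a 3.4-fold lower number from compound 1 to compound 3 (0.53 log units; beyond the scatter), a modest step of about the same size as the one seen with tert-butyl. Until now only tert-butyl had been compared with hydrogen at this place; with these three compounds, a single bromine atom does as much as the four carbons of tert-butyl, and both groups stand apart from hydrogen by more than the scatter. Nothing available explains why the two groups read alike, so the result stays an observation without a known cause.

Tert-butyl and bromo both carry no hydrogen-bond donors or acceptors and no net charge, so the compounds shown leave open how an amine or a carboxylic acid on this aromatic carbon would read. They also leave open whether a methoxy group or a longer chain there would stay level with these two or move the number further.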